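Naphthalen-1-yl for phenyl: a small change, a guarded forecast

The source may hold more compounds than are shown below. What is called first, only, known or untested is meant among the compounds shown, and "the series" means these compounds.

Compound 1, `COc1ccc(C2CC(c3ccc(OCc4cn(Cc5ccc([N+](=O)[O-])cc5)nn4)cc3)=NN2C(C)=O)cc1`: 15%
Compound 2, `COc1cc(C2CC(c3ccccc3)=NN2C(C)=O)ccc1OCc1cn(Cc2ccc([N+](=O)[O-])cc2)nn1`: 0%

Of the compounds shown here, two have been measured in a functional assay on THP-1 cells (Homo sapiens) for inhibition, read by sulforhodamine B assay, tested at 10 uM; on this read-out lower numbers stand for less inhibition of growth and higher numbers for more inhibition of growth at the one concentration tested. Compound 1 gives 15%, while compound 2 gives 0%, the lower of the two numbers, and the gap between them is beyond the usual scatter of this kind of measurement. Within the data shown here, the two differ from each other in more than one place, so no single step between measured compounds shows what one change alone does.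

Compound 3, `COc1cc(C2CC(c3cccc4ccccc34)=NN2C(C)=O)ccc1OCc1cn(Cc2ccc([N+](=O)[O-])cc2)nn1`, differs from compound 2 in one place only: naphthalen-1-yl in place of phenyl on a carbon with a double bond to nitrogen. Among the measured compounds shown here, nothing among the measured compounds tells how such a swap moves growth inhibition. In this assay the step is therefore expected to be small, at most a modest rise, quite possibly none beyond the scatter. Compound 3 is expected to give 8%, in a range from 0% to 25%. The estimated step of a number 8 percentage points higher from compound 2 to compound 3 (within the scatter) reflects that cautious view.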

Compound 3, percent growth inhibition at one concentration: 10%
Beside the measured number, compound 3's estimate is 2 percentage points below it; the measured number falls inside the stated range.
By their numbers in this assay, from the lowest: compounds 2, 3 and 1 (each within the scatter of the next, the first and the last beyond it).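

Among these compounds, compound 2 and compound 3 give the first single-change comparison here. Replacing phenyl with naphthalen-1-yl on a carbon with a double bond to nitrogen adds a second six-membered aromatic ring of carbon only, and in this assay the result is a number 10 percentage points higher from compound 2 to compound 3 (within the scatter). The larger group therefore keeps the read-out within the scatter of the phenyl compound, so neither a gain nor a loss can be claimed, and no other measurement offers an explanation for the result.

Going by these compounds, it remains open whether a group of a different kind at this position, such as an aminomethyl group or a carboxylic acid, would move growth inhibition beyond the scatter. On these data alone, it is also open whether naphthalen-1-yl would give a similar result on the core of compound 1.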